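This account rests on a few compounds, and the source may have more. Where it says the series, first, only, none or still open, it means among the compounds named here.

Of the compounds shown here, three built on a shared core have been tested in a functional assay on Hs-578T cells (Homo sapiens) for cytotoxicity, read by sulforhodamine B assay, with a stated time of 48 h; a lower number here means a stronger inhibitor of growth, a higher number a weaker inhibitor of growth. Compound 1 `Nc1nc(Cl)c2ncn(Cc3ccc(CCl)cc3)c2n1` gives 29500 nM in this assay. Compound 2 `ClCc1cccc(Cn2cnc3c(Cl)nc(Cl)nc32)c1` gives 1990 nM, and compound 3 `ClCc1ccc(Cn2cnc3c(Cl)nc(Cl)nc32)cc1` gives 2140 nM. Compound 2 and compound 3 are made of the same atoms joined differently; the difference between the two cores is not broken down here, and their two values lie within the scatter of each other.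

Compound 3 and compound 1 differ in one place: amino in place of chloro on an aromatic carbon. That single change produced a 14-fold higher number from compound 3 to compound 1 (1.14 log units; beyond the scatter), a large weakening of growth inhibition.

Compound 4 `Nc1nc(Cl)c2ncn(Cc3cccc(CCl)c3)c2n1` has not yet been measured. It stands to compound 2 exactly as compound 1 stands to compound 3: amino in place of chloro on an aromatic carbon. The surroundings of the changed carbon are described in the same words for both pairs, so this is the same change, not merely the same kind of change. The expectation for compound 4 rests on two things: compound 2 gives 1990 nM, and the same change already gave a 14-fold higher number from compound 3 to compound 1 (1.14 log units; beyond the scatter). The expected step is therefore a 14-fold higher number from compound 2 to compound 4 (1.15 log units; beyond the scatter). Compound 4 is estimated at 28000 nM, with a likely range from 10000 nM to 80000 nM, since a single earlier example of the change cannot fix the size of the step tightly.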

Compound 4, concentration for 50% growth inhibition: 11500 nM
The estimate for compound 4 lay 2.4-fold (0.39 log units) above the measured number; the measured number falls inside the stated range.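

In this assay, putting amino in place of chloro on the aromatic carbon again weakened growth inhibition, this time giving a 5.8-fold higher number from compound 2 to compound 4 (0.76 log units; beyond the scatter). The direction of the change therefore carried over from one core to the other, and although one step counts as large and the other as modest, the gap in their sizes is no greater than repeated measurements of such steps would be expected to produce: the same change on two cores in this assay, a 14-fold higher number (1.14 log units; beyond the scatter) from compound 3 to compound 1 and a 5.8-fold higher number (0.76 log units; beyond the scatter) from compound 2 to compound 4, 2.4-fold (0.38 log units) apart, within the scatter of two such steps. Among these compounds, this agreement rests on only two pairs of compounds, so it supports carrying the change across these two closely related cores, but it does not show how the change would behave on any other core, and it does not explain why the amino compounds are the weaker ones.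

The compounds shown leave open whether a different group on that same carbon, such as methoxy or methylamino, would weaken growth inhibition as much as amino does. They also leave open how the step would look if the chloromethyl group were exchanged for a plain methyl or a hydroxymethyl group, and whether it would hold in other cell lines.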